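The source may report more compounds than this note shows. Statements on the series, on what has been measured and on what is new or still open speak of the compounds shown alone.

Working notes on the shared core. Compound 1 `CC(C)=CC(=O)Nc1c(C(O)(C(F)(F)F)C(F)(F)F)ccc2ccccc12`, compound 2 `O=C(Nc1c(C(O)(C(F)(F)F)C(F)(F)F)ccc2ccccc12)C1CCCC1` and compound 3 `CC(C)OC(=O)Nc1c(C(O)(C(F)(F)F)C(F)(F)F)ccc2ccccc12` differ only in the group on the carbonyl carbon of the amide. In an assay on LtK cells with ATP-sensitive inward rectifier potassium channel 11 (Homo sapiens) as the target (on this read-out higher numbers stand for an effect only at larger amounts of compound and lower numbers for an effect already at smaller amounts), compound 1 gives 46 nM, compound 2 gives 495 nM and compound 3 gives 1160 nM. Compound 2 thus holds the second highest of the three numbers: a 2.3-fold higher number from compound 2 to compound 3 (0.37 log units; beyond the scatter), while an 11-fold higher number from compound 1 to compound 2 (1.03 log units; beyond the scatter). The remaining step, a 25-fold higher number from compound 1 to compound 3 (1.40 log units; beyond the scatter), is the largest in the set.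

Compound 4 `O=C(Nc1c(C(O)(C(F)(F)F)C(F)(F)F)ccc2ccccc12)c1cccc(C(F)(F)F)c1` has not yet been measured. Relative to compound 2 the change is 3-(trifluoromethyl)phenyl in place of cyclopentyl on a carbonyl carbon. All three measured steps alter this same carbonyl substituent, but none of them brings in a six-membered aromatic ring, so they bound the question only loosely: they show steps ranging from a 2.3-fold higher number from compound 2 to compound 3 (0.37 log units; beyond the scatter) to a 25-fold higher number from compound 1 to compound 3 (1.40 log units; beyond the scatter). Without direct precedent, a step in either direction within that span is plausible. The step expected here is a 1.7-fold lower number from compound 2 to compound 4 (0.22 log units; within the scatter), with wide uncertainty. Compound 4 is estimated at 300 nM, range 60 nM to 1500 nM.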

Compound 4, half-maximal effective concentration: 84 nM
Estimate against measurement, compound 4: 3.6-fold (0.55 log units) above; the measured number falls inside the stated range.
By their numbers in this assay, from the lowest: compounds 1 and 4 (each within the scatter of the next); then compound 2; then compound 3.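

The step of a 5.9-fold lower number from compound 2 to compound 4 (0.77 log units; beyond the scatter) and the step of a 14-fold lower number from compound 3 to compound 4 (1.14 log units; beyond the scatter) show in this assay that a six-membered aromatic ring is tolerated on this carbonyl carbon, and that 3-(trifluoromethyl)phenyl gives a lower number than either cyclopentyl or isopropoxy. With a 1.8-fold higher number from compound 1 to compound 4 (0.26 log units; within the scatter) as the remaining step, the 3-(trifluoromethyl)phenyl of compound 4 and the 2-methylprop-1-en-1-yl of compound 1 cannot be told apart, so two differently built groups reach the same low range at this place. Nothing given here accounts for these differences.

The compounds shown leave open how much of the result belongs to the trifluoromethyl group and how much to the aromatic ring, which plain phenyl would test. Also open, going by these compounds, is how a ring carrying an amine or a carboxylic acid would behave on this carbonyl carbon.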